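This account rests on a few compounds, and the source may have more. Where it says the series, first, only, none or still open, it means among the compounds named here.

Compound 3 `Nc1scc(CN2CCN(c3cc(F)cc(F)c3)CC2)c1C(=O)c1ccc(Cl)cc1` gives -13% in a functional assay on CHO cells with adenosine receptor A1 (Homo sapiens) as the target, read by cAMP accumulation and immunoassay, with a stated time of 6 min, tested at 0.01 uM (on this read-out lower numbers stand for a stronger effect and higher numbers for a weaker effect at the one concentration tested), the lowest of the three numbers shown. Compound 2 `COc1ccc(N2CCN(Cc3csc(N)c3C(=O)c3ccc(Cl)cc3)CC2)cc1` gives -1.2% and compound 1 `CC(C)N1CCN(Cc2csc(N)c2C(=O)c2ccc(Cl)cc2)CC1` gives -1% in this assay. Both steps onto the 3,5-difluorophenyl lie beyond the scatter, a number 12 percentage points lower from compound 1 to compound 3 (beyond the scatter) and a number 11.8 percentage points lower from compound 2 to compound 3 (beyond the scatter), whereas a number 0.2 percentage points lower from compound 1 to compound 2 (within the scatter). Compound 4 `Nc1scc(CN2CCN(c3cc(F)ccc3F)CC2)c1C(=O)c1ccc(Cl)cc1` has the same atoms as compound 3, joined differently: 2,5-difluorophenyl in place of 3,5-difluorophenyl on an amine nitrogen in a ring. For the measured compounds named here, no measured step moves a fluorine on this aryl group, so the two steps that bear on it show only that a difluorophenyl on the ring nitrogen sits lower than the isopropyl or the 4-methoxyphenyl. For compound 4 a step of a number 4 percentage points higher from compound 3 to compound 4 (within the scatter) is expected, with wide uncertainty. Compound 4 is estimated at -9%, between -20% and 2%.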

Compound 4, a percentage reported as activity, at one concentration (the size of the read-out at that concentration, not a potency): 3.1%
Compound 4: the middle estimate sits 12.1 percentage points below what was measured, and the stated range ends below it.
By their numbers in this assay, from the lowest: compound 3; then compounds 2, 1 and 4 (each within the scatter of the next).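

Moving the fluorines alone changes the result in this assay (a number 16.1 percentage points higher from compound 3 to compound 4 (beyond the scatter)), so the lower number belongs to the 3,5-difluorophenyl and not to difluorophenyl groups in general. The 2,5-difluorophenyl does not separate from the other two groups on the ring nitrogen (a number 4.3 percentage points higher from compound 2 to compound 4 (within the scatter); a number 4.1 percentage points higher from compound 1 to compound 4 (within the scatter)). Nothing available accounts for this difference between the two fluorine patterns.

Open, from the compounds shown here alone, is whether the lower number needs fluorine at all, or whether a 3,5-dichlorophenyl or a 3,5-dimethylphenyl on the ring nitrogen would give it too.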